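Trichlorophenyl to fluorophenyl on the propyl sulfonate series

A few compounds are considered here, and "the series" means these few. Any claim that something is new, unique, unknown or untested is made for them only; others in the source may bear on it.

Compound 3 `CCCN1CCN(c2ccc(S(=O)(=O)Oc3cc(Cl)c(Cl)cc3Cl)cc2)C1=O` gives 13000 nM in a functional assay on MCF7 cells (Homo sapiens) for antiproliferative activity, read by sulforhodamine B assay, with a stated time of 48 h (a higher number here means a weaker inhibitor, a lower number a stronger inhibitor), the highest of the three numbers in hand. For the measured compounds named here, compound 1 `CN1CCN(c2ccc(S(=O)(=O)Oc3cc(Cl)c(Cl)cc3Cl)cc2)C1=O` gives 630 nM, and the single change a 21-fold higher number from compound 1 to compound 3 (1.31 log units; beyond the scatter) is what separates them. Going by the values given here, compound 2 `CN1CCN(c2ccc(S(=O)(=O)Oc3cccc(Cl)c3)cc2)C1=O` gives 2200 nM and, against compound 1, shows that a 3-chlorophenyl in place of the 2,4,5-trichlorophenyl goes with a weaker inhibitor, though no single step between these two is counted here.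

Compound 4 `CCCN1CCN(c2ccc(S(=O)(=O)Oc3ccc(F)cc3)cc2)C1=O` differs from compound 3 in one place: 4-fluorophenyl in place of 2,4,5-trichlorophenyl on an oxygen. Among the compounds with values here, no measured step covers this exact exchange. The nearest hint is the pair of compound 1 and compound 2, where fewer chlorines on this ring went with a higher number. On that basis compound 4 is expected to sit above compound 3, with the step of a 3.1-fold higher number from compound 3 to compound 4 (0.49 log units; beyond the scatter) estimated to be moderate and upward. The estimate for compound 4 in this assay is 40000 nM, within a range from 12000 nM to 150000 nM.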

Compound 4, half-maximal inhibitory concentration: 33000 nM
Estimate against measurement, compound 4: 1.2-fold (0.08 log units) above; low and high end bracket the measured number.
By their numbers in this assay, from the lowest: compound 1; then compound 2; then compound 3; then compound 4.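

With the propyl chain kept, 4-fluorophenyl in place of 2,4,5-trichlorophenyl on the oxygen bound to the sulfonyl sulfur gives a 2.5-fold higher number from compound 3 to compound 4 (0.40 log units; beyond the scatter) in this assay, so this position still moves the read-out when the chain is propyl. Compound 1 and compound 2, both with the methyl group, had varied this ring only among chlorinated phenyls, and the new pair extends the same direction to a fluorinated ring: in both pairs, the ring with fewer halogen atoms carries the higher number. Nothing measured here explains the step.

The compounds shown leave open whether 4-fluorophenyl would give a similar change on the methyl compound. They also leave open how an unsubstituted phenyl, or a phenyl bearing an amine or a carboxylic acid, would behave on this oxygen.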